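A few compounds are considered here, and "the series" means these few. Any claim that something is new, unique, unknown or untested is made for them only; others in the source may bear on it.

Compound 1 `Nc1cc(N)c2nc(-c3ccccc3)c(Sc3ccc(F)cc3)nc2c1`: 28200 nM
Compound 2 `CCOC(=O)[C@H](CCC(=O)O)NC(=O)c1ccc(CNc2nc3cc(N)cc(N)c3nc2-c2ccccc2)cc1`: < 100000 nM

In a functional assay on HCT-116 cells (Homo sapiens) for inhibition, read by sulforhodamine B assay, with a stated time of 48 h (a lower number here means a stronger inhibitor of growth, a higher number a weaker inhibitor of growth), compound 1 gives 28200 nM, the only number shown. For compound 2 the assay reports no number but a limit, < 100000 nM. One of the two values sits at the limit of < 100000 nM in this assay, at which 1 of the 2 values shown sits. Compound 3 `Nc1cc(N)c2nc(-c3ccccc3)c(NCc3ccc(F)cc3)nc2c1` differs from compound 1 in one place: (4-fluorobenzyl)amino in place of (4-fluorophenyl)sulfanyl on an aromatic carbon. Among the measured compounds shown here, no measured pair shows this change, so the step is estimated at a 1.4-fold higher number from compound 1 to compound 3 (0.15 log units; within the scatter), a small weakening that may fall within the scatter. Compound 3 is therefore expected near 40000 nM, between 10000 nM and 120000 nM.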

Compound 3, concentration for total growth inhibition: < 100000 nM
Compound 3 ended at the assay's limit (the forecaster's own chance of this, stated with the estimate: 25%); the middle value is on the limit's open side.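

In this assay, among the compounds shown here, compound 3 gives < 100000 nM, which is a limit and not a number, so no step between compound 1 and compound 3 can be read. The compounds shown leave open whether (4-fluorobenzyl)amino in place of (4-fluorophenyl)sulfanyl changes growth inhibition at all.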